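The source may report more compounds than this note shows. Statements on the series, on what has been measured and on what is new or still open speak of the compounds shown alone.

Working notes on the series.

Compound 3 `COc1ccc(C2=NN(C3=NC(=O)/C(=C4\C(=O)Nc5ccccc54)S3)C(c3ccc(OC)cc3)C2)cc1` stands at the weakest end of the three numbers measured in a functional assay on cells (Cancer cell lines, Homo sapiens) for cytotoxicity, read by sulforhodamine B assay, with a stated time of 48 h; on this read-out higher numbers stand for weaker inhibition of growth and lower numbers for stronger inhibition of growth: compound 3 gives 91600 nM, the highest value seen. For the measured compounds named here, the nearest neighbour is compound 2 `COc1ccc(C2CC(c3ccccc3)=NN2C2=NC(=O)/C(=C3\C(=O)Nc4ccccc43)S2)cc1`, which in this assay gives 6040 nM; the single measured step, a 15-fold higher number from compound 2 to compound 3 (1.18 log units; beyond the scatter), is the methoxy in place of hydrogen on an aromatic carbon. Furthest away is compound 1 `O=C1N=C(N2N=C(c3ccccc3)CC2c2ccccc2O)S/C1=C1/C(=O)Nc2ccc(Br)cc21`, which in this assay gives 670 nM; compound 1 differs from compound 3 in more than one place, so its values say only that a halogen-bearing core can sit at a much lower number in this set.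

The step now considered leads to compound 4 `COc1ccc(C2=NN(C3=NC(=O)/C(=C4\C(=O)Nc5ccc(Cl)cc54)S3)C(c3ccc(OC)cc3)C2)cc1`. The change is chloro in place of hydrogen on an aromatic carbon; it sits on an aromatic carbon of a six-membered aromatic ring of carbon only, part of a fused system of two rings, meta to a fused ring and para to a fused ring. Going by the values given here, no measured step changes this position on an otherwise fixed scaffold, so nothing directly bears on it. Among the compounds with values here, the one measured step concerns a different ring and gives no direction for a halogen here.

Within the data shown here, compound 4 is therefore expected near 40000 nM, within 8000 nM to 150000 nM, a step of a 2.3-fold lower number from compound 3 to compound 4 (0.36 log units; beyond the scatter) that is an estimate only, with the low number of compound 1 670 nM as the sole hint that the value could fall.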

Compound 4, concentration for total growth inhibition: 440 nM
Estimate against measurement, compound 4: 91-fold (1.96 log units) above; the whole stated range lies above it.
By their numbers in this assay, from the lowest: compounds 4 and 1 (each within the scatter of the next); then compound 2; then compound 3.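

For the compounds shown here, this position is far from silent: chloro in place of hydrogen, on an aromatic carbon of a six-membered aromatic ring of carbon only, part of a fused or bridged system of two rings, gives a 210-fold lower number from compound 3 to compound 4 (2.32 log units; beyond the scatter) in this assay, the first measured change at this place on an otherwise fixed scaffold. Going by these compounds alone, the step runs opposite in direction to the only other measured step, a 15-fold higher number from compound 2 to compound 3 (1.18 log units; beyond the scatter), which lies on a different ring, and it is the larger of the two, so a single heavy atom at this carbon can move the read-out strongly in the direction of stronger inhibition of growth. Nothing available explains the size of this step.

The compounds shown leave open whether the step belongs to chloro itself or would also appear with another group at this carbon, such as fluoro, methyl or an amine. They also leave open whether the chloro step keeps its size on a scaffold with hydrogen in place of one or both methoxy groups, since it is known from a single pair.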